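A few compounds are considered here, and "the series" means these few. Any claim that something is new, unique, unknown or untested is made for them only; others in the source may bear on it.

Compound 1 `O=C1C=COC(/C=C/c2ccccc2)C1` and compound 2 `O=C1C=COC(/C=C/c2ccc(C(F)(F)F)cc2)C1` share one core, and compound 3 `O=C1C=CCC(/C=C/c2ccccc2)N1` and compound 4 `O=C1C=CCC(/C=C/c2ccccc2C(F)(F)F)N1` share another; how the two cores differ is not broken down here. In an ADME assay on HaCaT cells (Homo sapiens) for inhibition, read by sulforhodamine B assay, with a stated time of 48 h (on this read-out lower numbers stand for stronger inhibition of growth and higher numbers for weaker inhibition of growth), compound 1 gives 127 uM. In this assay compound 2 gives 123 uM. The change between them is trifluoromethyl in place of hydrogen on an aromatic carbon, and it made a 1.0-fold lower number from compound 1 to compound 2 (0.01 log units; within the scatter). For compound 3 this assay reports only a limit, > 1250 uM, which is the limit of > 1250 uM in this assay, at which 1 of the 3 values shown sits. Compound 4 carries the same kind of change relative to compound 3, namely (trifluoromethyl in place of hydrogen on an aromatic carbon), though here the trifluoromethyl stands ortho to a group of 9 heavy atoms, whereas in compound 2 it stands para to a group of 9 heavy atoms. Since the change from compound 1 to compound 2 stayed within the scatter, and compound 3 already sits at the limit > 1250 uM, the step from compound 3 to compound 4 is expected to be a step that the limit leaves unreadable from compound 3 to compound 4 in this assay. Compound 4 is therefore estimated at 1500 uM in this assay, most likely again reported only as a limit, with a range from 700 uM to 3500 uM.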

Compound 4, concentration for growth inhibition (reported as GI): 249 uM
Estimate against measurement, compound 4: 6.0-fold (0.78 log units) above; measured number below the stated range.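

In this assay, trifluoromethyl in place of hydrogen on an aromatic carbon gave an at least 5.0-fold lower number from compound 3 to compound 4 (0.70 log units; beyond the scatter), and the true size of that step stays open, for compound 3 is held only as a limit: the limit of > 1250 uM in this assay, at which 1 of the 4 values shown sits.

Set beside the earlier step, the same change did not carry over from one core to the other at the same size: the same change on two cores in this assay, a 1.0-fold lower number (0.01 log units; within the scatter) from compound 1 to compound 2 and an at least 5.0-fold lower number (0.70 log units; beyond the scatter) from compound 3 to compound 4, at least 4.8-fold (0.68 log units) apart, beyond the scatter of two such steps

The two steps also differ in where the group sits, ortho to a group of 9 heavy atoms in compound 4 only, so the data do not separate core from position and give no cause for the gap.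

The compounds shown leave open what trifluoromethyl would do at that same place on the core of compound 1, or at the place it holds in compound 2 on the core of compound 3. Also open, as far as these compounds go, is how a chlorine, a methoxy group or an amine in place of that hydrogen would behave on either core.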